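Replacing isopropyl with phenyl: working notes

The source may report more compounds than this note shows. Statements on the series, on what has been measured and on what is new or still open speak of the compounds shown alone.

In a physicochemical assay for lipophilicity, read by HPLC, using the shake flask method (on this read-out higher numbers stand for higher lipophilicity and lower numbers for lower lipophilicity), compound 1 `CC/C(=N\C#N)N(C)Cc1ccc(Cl)nc1` gives 1.12 and compound 2 `CC(C)/C(=N\C#N)N(C)Cc1ccc(Cl)nc1` gives 1.39, two values within the scatter of each other. Within the data shown here, compound 2 therefore stands level with the only other measured compound. Compound 3 `CN(Cc1ccc(Cl)nc1)/C(=N/C#N)c1ccccc1` differs from compound 2 as follows: phenyl in place of isopropyl on a carbon with a double bond to nitrogen. In words, this is phenyl in place of isopropyl on a carbon with a double bond to nitrogen. Among the measured compounds shown here, one measured step bears on this change, only indirectly: a number 0.27 log units higher from compound 1 to compound 2 (within the scatter), with methyl in place of hydrogen on a saturated chain carbon. For the measured compounds named here, no measured compound carries a ring at this place, so the precedent is weak. A modest upward step is expected in this assay, and the expected size is a number 0.31 log units higher from compound 2 to compound 3 (beyond the scatter). For compound 3 the estimated value is 1.7, with an expected range of 1.25 to 2.2.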

Compound 3, partition coefficient: 1.86
Compound 3: middle estimate off by 0.16 log units, on the low side; measured number inside the range.
By their numbers in this assay, from the lowest: compounds 1 and 2 (each within the scatter of the next); then compound 3.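

In this assay phenyl in place of isopropyl on a carbon with a double bond to nitrogen gives a number 0.47 log units higher from compound 2 to compound 3 (beyond the scatter) and so produces a step beyond the scatter at this place, which the earlier chain change did not. Phenyl in place of ethyl at the same place gives a number 0.74 log units higher from compound 1 to compound 3 (beyond the scatter) and is the larger of these two steps. Compound 3 therefore stands apart from compound 1 and compound 2, which remain level with each other. Nothing available explains these steps.

Phenyl is the only ring shown at this place, so it remains open whether the steps are particular to phenyl. As far as these compounds go, how a longer chain such as butyl, or an amine, would read at this place also remains open.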